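The source may report more compounds than this note shows. Statements on the series, on what has been measured and on what is new or still open speak of the compounds shown alone.

Measured so far:
- compound 1, `c1cncc(CN(CCCCN(C[C@H]2Cc3ccccc3CN2)[C@H]2CCCc3cccnc32)Cc2cccnc2)c1`: 471 nM
- compound 2, `O=S1(=O)CCC(CNCCCCN(C[C@H]2Cc3ccccc3CN2)[C@H]2CCCc3cccnc32)CC1`: 17 nM

Both compounds share one core and differ only in the group carried on the chain beyond the second amine nitrogen. In a functional assay on cells for antagonist activity at C-X-C chemokine receptor type 4 (Homo sapiens), read by fluorescence and calcium flux, with stated times of 25 min and 90 s (on this read-out higher numbers stand for weaker inhibition and lower numbers for stronger inhibition), compound 2 gives 17 nM, the lower of the two numbers; compound 1 gives 471 nM in this assay, and the gap between the two lies well beyond the usual scatter, so compound 2 is the stronger of the pair. Going by the values given here, no single-point step between the measured compounds is available, so the weight of this part of the molecule can only be read from what the two values show.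

Compound 3, `CC(C)(N)CCCN(C[C@H]1Cc2ccccc2CN1)[C@H]1CCCc2cccnc21`, is not yet measured in this assay. It departs from compound 2 by a group of 4 heavy atoms (3 carbon, 1 nitrogen; no ring) in place of a group of 11 heavy atoms (7 carbon, 1 nitrogen, 2 oxygen, 1 sulfur; one six-membered non-aromatic ring with 1 hetero atom), on a saturated chain carbon, three bonds along the chain from an amine nitrogen. The piece that leaves is the larger one and carries the sulfur-bearing ring; what enters is small and open-chain, still with one hydrogen-bond donor and one acceptor. Nothing in the measured pair isolates this position, so the size of the step is uncertain; a moderate loss beyond the scatter is expected, with a 4.1-fold higher number from compound 2 to compound 3 (0.61 log units; beyond the scatter) as the estimated step from compound 2 to compound 3 in this assay. Compound 3 is therefore expected to give about 70 nM in this assay, within a range of 12 nM to 400 nM.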

Compound 3, half-maximal inhibitory concentration: 24.6 nM
The estimate for compound 3 lay 2.8-fold (0.45 log units) above the measured number; the range from low to high includes it.
By their numbers in this assay, from the lowest: compounds 2 and 3 (each within the scatter of the next); then compound 1.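

In this assay the exchange on a saturated chain carbon, three bonds along the chain from an amine nitrogen, gives a 1.4-fold higher number from compound 2 to compound 3 (0.16 log units; within the scatter), so the two groups cannot be told apart on this read-out. The open-chain 1-amino-1-methylethyl group, with 4 heavy atoms, reads on a level with the group of 11 heavy atoms and its six-membered non-aromatic ring, which shows that neither that ring nor its sulfur and two oxygens is needed at this position for a value in this range, something the earlier pair could not show. No measurement at hand accounts for this outcome.

Open, from the compounds shown here alone, is how this assay would read with a hydroxyl group in place of the amino group of the 1-amino-1-methylethyl group, and with a plain aminomethyl group in place of the whole 1-amino-1-methylethyl group. Also open, going by these compounds, is whether a longer chain carrying the same amine would stay on this level.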